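A few compounds are considered here, and "the series" means these few. Any claim that something is new, unique, unknown or untested is made for them only; others in the source may bear on it.

Measured so far in an assay on isolated protein for inhibition of ribosomal protein S6 kinase beta-1 (Homo sapiens); a higher number here means a weaker inhibitor, a lower number a stronger inhibitor:
compound 1 `C[C@@H]1CC(=O)Nc2ncnc(N3CCC(c4nc(C(F)(F)F)cn4CCN4CCCC4)CC3)c21`: 876 nM
compound 2 `C[C@@H]1CC(=O)Nc2ncnc(N3CCC(c4nc(C5CCOCC5)cn4CCN4CCCC4)CC3)c21`: 1900 nM

Going by the values given here, of these two numbers compound 2 stands highest in this assay; its nearest neighbour is compound 1, and the single step between them, a 2.2-fold higher number from compound 1 to compound 2 (0.34 log units; beyond the scatter), came from putting oxan-4-yl in place of trifluoromethyl on an aromatic carbon of the five-membered aromatic ring.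

The next compound is compound 3 `C[C@@H]1CC(=O)Nc2ncnc(N3CCC(c4nc(CCC(F)(F)F)cn4CCN4CCCC4)CC3)c21`. Its change from compound 2 is 3,3,3-trifluoropropyl in place of oxan-4-yl on an aromatic carbon. Among the compounds with values here, the only measured step that bears on it is the one from compound 1 to compound 2, which exchanged a fluorine-bearing group for the oxan-4-yl group and gave a modest rise in the number. The step to compound 3 partly reverses that exchange: the oxan-4-yl group leaves again and a fluorine-bearing chain enters, though one different from trifluoromethyl. A modest lowering of the number is therefore expected, of about the size seen in a 2.2-fold higher number from compound 1 to compound 2 (0.34 log units; beyond the scatter) but in the opposite direction, and the estimated step is a 1.9-fold lower number from compound 2 to compound 3 (0.28 log units; within the scatter).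

For compound 3 the expected value in this assay is 1000 nM, with a range from 400 nM to 2500 nM.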

Compound 3, half-maximal inhibitory concentration in the ribosomal protein S6 kinase beta-1 assay: 399 nM
Compound 3: middle estimate off by 2.5-fold (0.40 log units), on the high side, outside the stated range (below it).
By their numbers in the ribosomal protein S6 kinase beta-1 assay, from the lowest: compound 3; then compound 1; then compound 2.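

In the ribosomal protein S6 kinase beta-1 assay the aromatic carbon of the five-membered aromatic ring gives its lowest number of the three with the open-chain 3,3,3-trifluoropropyl group, through a 4.8-fold lower number from compound 2 to compound 3 (0.68 log units; beyond the scatter) and a 2.2-fold lower number from compound 1 to compound 3 (0.34 log units; beyond the scatter). Oxan-4-yl and 3,3,3-trifluoropropyl carry equal heavy-atom counts yet stand at the two ends of the series, so heavy-atom count alone does not order these compounds, and trifluoromethyl, the smallest group shown, falls in the middle. In a physicochemical assay for solubility, at pH 7.4 (a higher number here means a more soluble compound, a lower number a less soluble compound), compound 2 gives > 2000 ug/mL, which is a limit of the assay and not a number. In the physicochemical assay compound 3 gives 990 ug/mL. In the physicochemical assay the same change reads as an at least 2.0-fold lower number from compound 2 to compound 3 (0.30 log units; that floor lies within the scatter), which is only a floor, set by the assay limit on compound 2: the limit of > 2000 ug/mL in the physicochemical assay, at which 1 of the 2 values shown sits.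

Going by these compounds, whether the fluorine atoms or the open chain carries the step stays open, and a plain propyl group or a longer fluorinated chain such as 4,4,4-trifluorobutyl on this carbon would separate the two. Also open, on these data alone, is whether this order holds once the 2-(pyrrolidin-1-yl)ethyl group, constant across all three compounds, gives way to another amine.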